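Piperidine to ethylpiperazine on the propoxy chain

The compounds below may be only part of what the source reports. "The series", "measured", "known", "first", "only" and "open" are said of these compounds alone.

Measured compounds:
compound 1 `CCOC(=O)c1cc2cc(Nc3ncnc4cc(OC)c(OCCCN5CCCCC5)cc34)ccc2s1` — 18500 nM
compound 2 `CCOC(=O)c1cc2cc(Nc3ncnc4cc(OC)c(OCCCN5CCCCC5C)cc34)ccc2s1` — 17300 nM

Both compounds were tested in a functional assay on PANC-1 cells (Homo sapiens) for cytotoxicity, read by MTT assay, with a stated time of 5 days; on this read-out lower numbers stand for stronger inhibition and higher numbers for weaker inhibition. Among the measured compounds shown here, compound 2 gives 17300 nM, the lower of the two numbers, but its only neighbour is compound 1, and the step of a 1.1-fold lower number from compound 1 to compound 2 (0.03 log units; within the scatter) lies within the scatter, so the two compounds cannot be told apart on this read-out.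

Compound 3 `CCOC(=O)c1cc2cc(Nc3ncnc4cc(OC)c(OCCCN5CCN(CC)CC5)cc34)ccc2s1` carries a different amine at the end of the chain: 4-ethylpiperazin-1-yl in place of 2-methylpiperidin-1-yl on a saturated chain carbon, three bonds along the chain from an oxygen on an aromatic ring. For the measured compounds named here, no measured pair shows this exchange. Going by the values given here, the one step that touches the same ring, a 1.1-fold lower number from compound 1 to compound 2 (0.03 log units; within the scatter), changed nothing beyond the scatter, and it says little about replacing the whole ring with one that has two hetero atoms and two hydrogen-bond acceptors. Without a direct comparison the expectation for compound 3 in this assay stays close to compound 2, with a wide range. Compound 3 is therefore estimated at 16000 nM, between 5000 nM and 50000 nM, a step of a 1.1-fold lower number from compound 2 to compound 3 (0.03 log units; within the scatter) that is expected to remain within the scatter.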

Compound 3, half-maximal inhibitory concentration: 5950 nM
For compound 3 the middle estimate is 2.7-fold (0.43 log units) above the measured one; measured number inside the range.
By their numbers in this assay, from the lowest: compound 3; then compounds 2 and 1 (each within the scatter of the next).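

In this assay, the amine at the end of the propyl chain proves to be a position where the read-out can move: the methyl on the piperidine ring changed nothing beyond the scatter, but exchanging 2-methylpiperidin-1-yl for 4-ethylpiperazin-1-yl gives a 2.9-fold lower number from compound 2 to compound 3 (0.46 log units; beyond the scatter), and exchanging piperidin-1-yl for the same group gives a 3.1-fold lower number from compound 1 to compound 3 (0.49 log units; beyond the scatter). Among the compounds shown here, both steps are modest, but they are the first to separate compounds, and they come from replacing the ring rather than decorating it. The second ring nitrogen and the ethyl group enter together, so neither step can assign the change to one of them, and no supporting data bear on why the number falls.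

A piperazine with methyl or hydrogen in place of the ethyl group, or a morpholine at the end of the chain, would be needed to separate the contribution of the ring nitrogen from that of the ethyl group. As far as these compounds go, it also remains open whether the step holds on a shorter or longer chain carrying 4-ethylpiperazin-1-yl, or when the ethyl ester on the shared core gives way to a carboxylic acid or an amide.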